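The source may hold more compounds than are shown below. What is called first, only, known or untested is meant among the compounds shown, and "the series" means these compounds.

Measured in a functional assay on MKN-74 cells (Homo sapiens) for antiproliferative activity, with a stated time of 24 h; a higher number here means a weaker inhibitor, a lower number a stronger inhibitor:
compound 1 `NC(=O)c1c(NC(=O)c2ccccc2Cl)sc2c1CCN(Cc1ccc([N+](=O)[O-])cc1)C2` gives 31500 nM
compound 2 `NC(=O)c1c(NC(=O)c2ccccc2Cl)sc2c1CCN(Cc1ccc(Cl)cc1Cl)C2` gives 16300 nM
compound 3 `NC(=O)c1c(NC(=O)c2ccccc2Cl)sc2c1CCN(Cc1cc(Cl)cc(Cl)c1)C2` gives 23700 nM

Compound 3 stands second highest of the three numbers, but a 1.3-fold lower number from compound 1 to compound 3 (0.12 log units; within the scatter) and a 1.5-fold higher number from compound 2 to compound 3 (0.16 log units; within the scatter) are both within the scatter, as is a 1.9-fold lower number from compound 1 to compound 2 (0.29 log units; within the scatter); the three compounds are not separated.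

Compound 4 `NC(=O)c1c(NC(=O)c2ccccc2Cl)sc2c1CCN(C(=S)Nc1ccccc1)C2` carries a group of 9 heavy atoms (7 carbon, 1 nitrogen, 1 sulfur; one six-membered aromatic ring of carbon only) in place of a group of 9 heavy atoms (7 carbon, 2 chlorine; one six-membered aromatic ring of carbon only), on an amine nitrogen in a ring. Going by the values given here, none of the measured steps touches this kind of change: all three vary only the substitution of a benzyl group and all stay within the scatter, so they say nothing about a thiourea in that place. Among the compounds with values here, with no step bearing on it, the expectation for compound 4 in this assay is a number in the same range as the measured three, with wide uncertainty: a 1.1-fold higher number from compound 3 to compound 4 (0.02 log units; within the scatter) is the estimated step. The estimate for compound 4 is 25000 nM, range 7000 nM to 90000 nM.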

Compound 4, half-maximal inhibitory concentration: 15600 nM
Compound 4: the middle estimate sits 1.6-fold (0.20 log units) above what was measured; measured number inside the range.
By their numbers in this assay, from the lowest: compounds 4, 2, 3 and 1 (each within the scatter of the next, the first and the last beyond it).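

In this assay, the thiourea on the amine nitrogen in a ring is not separated from the dichlorobenzyl groups: a 1.5-fold lower number from compound 3 to compound 4 (0.18 log units; within the scatter) and a 1.0-fold lower number from compound 2 to compound 4 (0.02 log units; within the scatter). Against the 4-nitrobenzyl group, a 2.0-fold lower number from compound 1 to compound 4 (0.31 log units; beyond the scatter) is the only step in the series beyond the scatter, and it is modest. No measurement on hand explains these results.

As far as these compounds go, whether an acyl group or a basic amine on this nitrogen would give a different number remains open. So does the effect of chlorine or methoxy on the thiourea's phenyl ring.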